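This account rests on a few compounds, and the source may have more. Where it says the series, first, only, none or still open, it means among the compounds named here.

Measured compounds:

compound 1 `N#Cc1ccc(Oc2cccnc2)cc1F` with 15% in an assay on isolated protein for inhibition of Aromatase (Homo sapiens), read by fluorescence, tested at 1 uM; a lower number here means less inhibition, a higher number more inhibition at the concentration tested (going by the name of the read-out)
compound 2 `N#Cc1ccc(Oc2cccnc2)cc1Oc1cccnc1` with 81% in this assay
compound 3 `N#Cc1ccc(Oc2cccnc2)c(Oc2cccnc2)c1` with 82% in this assay

Compound 2 and compound 3 are built from the same atoms joined differently; the difference between the two cores is not broken down here. Their values lie within the usual scatter of each other. Compound 1 stands apart: the change fluoro in place of (pyridin-3-yl)oxy on an aromatic carbon gave a number 66 percentage points lower from compound 2 to compound 1 (beyond the scatter).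

Compound 4 `N#Cc1ccc(Oc2cccnc2)c(F)c1` has not been measured. It differs from compound 3 by fluoro in place of (pyridin-3-yl)oxy on an aromatic carbon. This is the same kind of change as that from compound 2 to compound 1, not the same: in compound 1 the fluoro sits ortho to a cyano group and meta to a (pyridin-3-yl)oxy group, while in compound 4 it sits ortho to a (pyridin-3-yl)oxy group and meta to a cyano group.

A step of similar size is expected here, because the earlier step measured a number 66 percentage points lower from compound 2 to compound 1 (beyond the scatter). Compound 4 is therefore estimated to give 18%, between 5% and 40%, which corresponds to an expected step of a number 64 percentage points lower from compound 3 to compound 4 (beyond the scatter).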

Compound 4, a percentage reported as inhibition, at one concentration (the size of the read-out at that concentration, not a potency): 52%
Beside the measured number, compound 4's estimate is 34 percentage points below it, outside the stated range (above it).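

Replacing the (pyridin-3-yl)oxy group with fluoro lowers the number on this second core too, with a number 30 percentage points lower from compound 3 to compound 4 (beyond the scatter) in this assay, so the direction of the change carries over from one core to the other. The size does not carry over, as the two steps clearly differ: the same change on two cores in this assay, a number 66 percentage points lower (beyond the scatter) from compound 2 to compound 1 and a number 30 percentage points lower (beyond the scatter) from compound 3 to compound 4, 36 percentage points apart, beyond the scatter of two such steps. With only these two pairs, this shows that the earlier step could not simply be copied to the new core, but it does not show why, or whether the fluoro's place on the ring or something else about the two cores accounts for the gap.

Still open, as far as these compounds go, is how an amine or a methoxy group would behave in that place, and whether a plain hydrogen there would separate the loss of the (pyridin-3-yl)oxy group from the gain of fluoro. From the compounds shown here alone, each number is also a reading at a single concentration, so how these compounds compare in potency remains open as well.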